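The source may hold more compounds than are shown below. What is called first, only, known or untested is meant among the compounds shown, and "the series" means these compounds.

Measured compounds in a functional assay on isolated protein for agonist activity at Glucose-dependent insulinotropic receptor (Rattus norvegicus), read by HTRF and cAMP accumulation; on this read-out higher numbers stand for an effect only at larger amounts of compound and lower numbers for an effect already at smaller amounts:
- compound 1 `CC(C)(C)OC(=O)N1CCC(O[C@H]2CC[C@@H](Oc3ccc(S(C)(=O)=O)cc3)CC2)CC1` gives 1390 nM
- compound 2 `Cc1nc(S(C)(=O)=O)ccc1O[C@H]1CC[C@H](OC2CCN(C(=O)OC(C)C)CC2)CC1` gives 89 nM
- compound 3 `CC1(OC(=O)N2CCC(O[C@H]3CC[C@H](Oc4cnc(S(C)(=O)=O)cn4)CC3)CC2)CC1` gives 138 nM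

Among these three numbers compound 3 holds the second highest. Its nearest neighbour is compound 2, whose number is lower by an amount that stays within the usual scatter, so the two cannot be told apart. The furthest is compound 1, whose number is higher by an amount well beyond the scatter.

Compound 4 `CS(=O)(=O)c1cnc(O[C@H]2CC[C@H](OC3CCN(CC4(C(F)(F)F)CCC4)CC3)CC2)cn1` is not yet measured. It differs from compound 3 in one place: (1-(trifluoromethyl)cyclobutyl)methyl in place of ((1-methylcyclopropyl)oxy)carbonyl on an amine nitrogen in a ring. For the measured compounds named here, no pair of measured compounds differs by this kind of exchange, so there is no measured step to lean on; the three measured numbers span a range that a single change of this size could plausibly cover in either direction. The expectation is a modest shift towards a higher number, with wide uncertainty, so that the step from compound 3 to compound 4 is estimated at a 2.2-fold higher number from compound 3 to compound 4 (0.34 log units; beyond the scatter). For compound 4 in this assay the estimate is 300 nM, with a range from 70 nM to 1400 nM.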

Compound 4, half-maximal effective concentration: 80 nM
For compound 4 the middle estimate is 3.8-fold (0.57 log units) above the measured one; the measured number falls inside the stated range.
By their numbers in this assay, from the lowest: compounds 4, 2 and 3 (each within the scatter of the next); then compound 1.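

On the amine nitrogen in a ring, (1-(trifluoromethyl)cyclobutyl)methyl can take the place of ((1-methylcyclopropyl)oxy)carbonyl in this assay with a step of a 1.7-fold lower number from compound 3 to compound 4 (0.24 log units; within the scatter). This shows that the position can hold a group with no carbonyl and no hydrogen-bond acceptors, whereas the three earlier compounds all carry a carbonyl-containing group there and could not show this. Nothing measured here explains why the number stays within the scatter across this exchange.

Still open, on these data alone, is how a urea, a sulfonamide or a plain benzyl group on the same nitrogen would read out. Also open, as far as these compounds go, are what the trifluoromethyl group contributes, which a simple methyl in its place would test, and whether the exchange behaves the same way on the cores of compound 1 and compound 2.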